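This account rests on a few compounds, and the source may have more. Where it says the series, first, only, none or still open, it means among the compounds named here.

Measured so far:
compound 1, `COc1cccc(NC2=CC(=O)c3c(nc4n3[C@H]3OC[C@@H](O)[C@H]3OC4)C2=O)c1`, 1790 nM
compound 2, `Cc1ccc(NC2=CC(=O)c3nc4n(c3C2=O)[C@H]2OC[C@@H](O)[C@H]2OC4)cc1C`, 860 nM
compound 3, `CCc1ccc(NC2=CC(=O)c3nc4n(c3C2=O)[C@H]2OC[C@@H](O)[C@H]2OC4)cc1`, 1290 nM

These three compounds were tested in a functional assay on MGC-803 cells (Homo sapiens) for inhibition, read by sulforhodamine B assay; a lower number here means a stronger inhibitor, a higher number a weaker inhibitor. Compound 1 gives the highest of the three numbers; its gap to compound 3 lies within the scatter, while its gap to compound 2 lies just beyond it. Compound 4, `CCc1ccc(NC2=CC(=O)c3c(nc4n3[C@H]3OC[C@@H](O)[C@H]3OC4)C2=O)cc1`, has not yet been measured. It differs from compound 1 in one place: 4-ethylphenyl in place of 3-methoxyphenyl on an amine nitrogen. Among the measured compounds shown here, the only measured step that touches the entering group is a 1.5-fold higher number from compound 2 to compound 3 (0.18 log units; within the scatter), which swapped one aryl group for the 4-ethylphenyl group and stayed within the scatter. Compound 3 also carries a 4-ethylphenyl group, but it differs from compound 1 in its core as well, so its number cannot be read as a direct step. With so little to go on, no change beyond the scatter is expected for compound 4 in this assay, only a step of a 1.3-fold lower number from compound 1 to compound 4 (0.11 log units; within the scatter). Compound 4 is therefore estimated at 1400 nM, within the range 600 nM to 3500 nM.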

Compound 4, half-maximal inhibitory concentration: 1110 nM
Beside the measured number, compound 4's estimate is 1.3-fold (0.10 log units) above it, and the stated range covers the measured number.
By their numbers in this assay, from the lowest: compounds 2, 4, 3 and 1 (each within the scatter of the next, the first and the last beyond it).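

Within this assay the swap of 3-methoxyphenyl for 4-ethylphenyl on the amine nitrogen gives a 1.6-fold lower number from compound 1 to compound 4 (0.21 log units; within the scatter) and provides the first direct reading of an aryl change at this position on this core. The change removes the oxygen and its hydrogen-bond acceptor while keeping the same count of heavy atoms, yet the two numbers cannot be told apart, so this position tolerates this exchange without a clear shift in the assay. The data offer no measurement that could explain this result. Both aryl groups here are substituted phenyl rings with small groups on them, so the compounds shown do not say how far this tolerance extends. A phenyl ring carrying an amine or a carboxylic acid, or a chain longer than ethyl, might still move the number beyond the scatter.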